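Cytotoxicity of Three Pyrazoline Sulfonamides and a Fourth

A few compounds are considered here, and "the series" means these few. Any claim that something is new, unique, unknown or untested is made for them only; others in the source may bear on it.

Compound 1, `Cc1ccc(C2CC(c3ccc(OCc4ccccc4)cc3)=NN2c2ccc(S(N)(=O)=O)cc2)cc1`, gives 35000 nM in an ADME assay on MT4 cells (Homo sapiens) for cytotoxicity, read by MTT assay, with a stated time of 96 h; on this read-out lower numbers stand for higher toxicity in this test and higher numbers for lower toxicity in this test.
Compound 2, `Cc1cccc(C2CC(c3ccc(OCc4ccccc4)cc3)=NN2c2ccc(S(N)(=O)=O)cc2)c1`, gives 44000 nM.
Compound 3, `NS(=O)(=O)c1ccc(N2N=C(c3ccccc3)CC2c2ccccc2Cl)cc1`, gives 44000 nM.

All three numbers sit within a narrow band. Compound 3 stands level with compound 2 at the digits recorded, and the two together hold the highest numbers of the set, with compound 1 only marginally lower, within the scatter. Among the measured compounds shown here, the single one-place step among the measured compounds, a 1.3-fold higher number from compound 1 to compound 2 (0.10 log units; within the scatter), likewise stays within the scatter.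

Compound 4, `NS(=O)(=O)c1ccc(N2N=C(c3ccc(OCc4ccccc4)cc3)CC2c2ccccc2Cl)cc1`, differs from compound 3 by benzyloxy in place of hydrogen on an aromatic carbon. For the measured compounds named here, no measured step covers this change directly; compounds 1 and 2 already carry the benzyloxy group and their values lie close to that of compound 3, which carries none. What the data show is therefore a flat landscape: neither the swap of methylphenyl positions nor the presence or absence of benzyloxy has produced a step beyond the scatter. On that basis compound 4 is expected to land close to compound 3, with the step of a 1.1-fold lower number from compound 3 to compound 4 (0.04 log units; within the scatter) estimated to stay within the scatter. Compound 4 is estimated at 40000 nM, in a range from 20000 nM to 80000 nM.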

Compound 4, half-maximal cytotoxic concentration: 26000 nM
The estimate for compound 4 lay 1.5-fold (0.19 log units) above the measured number, within the range that was stated.
By their numbers in this assay, from the lowest: compounds 4, 1, 2 and 3 (each within the scatter of the next).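

In this assay the benzyloxy group on the aromatic carbon, para to a large group, can now be read directly: its entry in place of hydrogen gives a 1.7-fold lower number from compound 3 to compound 4 (0.23 log units; within the scatter), so on this core the added group, with its six-membered aromatic ring of carbon only, produces no step beyond the scatter. The saturated ring carbon can also now be read with benzyloxy present, since 2-chlorophenyl in place of 3-methylphenyl gives a 1.7-fold lower number from compound 2 to compound 4 (0.23 log units; within the scatter) and 2-chlorophenyl in place of 4-methylphenyl gives a 1.3-fold lower number from compound 1 to compound 4 (0.13 log units; within the scatter), which means that none of these three groups at that place separates from another beyond the scatter. No evidence on the reason for these readings is at hand.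

The compounds shown therefore leave open whether any change at either place can move the number beyond the scatter, as every step so far stays within it. Also open, as far as these compounds go, is how an amine or a carboxylic acid in place of the benzyloxy group would read, and whether a longer chain between the oxygen and the terminal ring would read any differently.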